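A few compounds are considered here, and "the series" means these few. Any claim that something is new, unique, unknown or untested is made for them only; others in the source may bear on it.

Measured in an ADME assay on PC-3 cells (Homo sapiens) for cytotoxicity, read by WST assay, tested at 100 uM; on this read-out lower numbers stand for less inhibition and higher numbers for more inhibition at the one concentration tested (going by the name of the read-out):

Compound 1 `CC(=O)c1cccc(NC(=O)C2CCCN(C(=O)c3cc(C(F)(F)F)cc(C(F)(F)F)c3)C2)c1`: 0%
Compound 2 `O=C(Nc1ccc(Cl)cc1)C1CCCN(C(=O)c2cccc(-c3cccs3)c2)C1`: 4%
Compound 3 `O=C(Nc1ccc(Cl)cc1)C1CCCN(C(=O)c2ccc(-c3ccco3)cc2)C1`: 6%

Compound 1 shares a core with compound 2 and compound 3, the three differing in the groups at either end of that core. In this assay compound 1 gives 0%, and the numbers of compound 2 and compound 3 lie within the usual scatter of it, so none of the three stands apart from the others; all three show little inhibition at the single concentration tested.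

Compound 4 `COc1cccc(NC(=O)C2CCCN(C(=O)c3cc(C(F)(F)F)cc(C(F)(F)F)c3)C2)c1` is the next compound and has not yet been measured. It differs from compound 1 in one place only: methoxy in place of acetyl on an aromatic carbon. Going by the values given here, no pair of measured compounds differing in a single place is available, so the effect of this kind of change has not been seen here.

Given that compound 1 gives 0% and its neighbours give similar small numbers, the step of a number 3 percentage points higher from compound 1 to compound 4 (within the scatter) is expected to stay within the scatter, in no particular direction. Compound 4 is therefore estimated at 3%, with a range from 0% to 12%.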

Compound 4, a percentage reported as inhibition, at one concentration (the size of the read-out at that concentration, not a potency): 0%
Beside the measured number, compound 4's estimate is 3 percentage points above it; low and high end bracket the measured number.
By their numbers in this assay, from the lowest: compounds 1, 4, 2 and 3 (each within the scatter of the next).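

Going by these compounds alone, replacing acetyl with methoxy gives the first comparison in which only one place differs in this assay, and it reads no change at the digits printed from compound 1 to compound 4 (within the scatter). At this aromatic carbon, meta to a large group, the two groups cannot be told apart in this read-out, even though the double bond outside the aromatic rings leaves with the acetyl. No supporting measurement is available to explain this outcome.

As far as these compounds go, it remains open whether an amine or a carboxylic acid on this carbon, or a longer chain ending in an ether oxygen, would also stay within the scatter of compound 1. From the compounds shown here alone, it is also open whether the same exchange would read alike on compounds carrying different groups at the far end of the shared core.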